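This account rests on a few compounds, and the source may have more. Where it says the series, first, only, none or still open, it means among the compounds named here.

Among the compounds with values here, compound 1 `N#Cc1c(-c2ccc(Cl)cc2)nc(SCC(=O)Nn2c(COc3ccc(Cl)cc3Cl)nc3ccccc3c2=O)[nH]c1=O` is one of two compounds measured so far; in a functional assay on the whole organism (strain albino) for inhibition, with Rattus norvegicus as the target, read by paw edema, with stated times of 1 h and 3 h, at a dose of 100 mg/kg by the oral route (a lower number here means a weaker effect, a higher number a stronger effect of the compound at the dose given), compound 1 gives 64.9%. Within the data shown here, compound 2 `N#Cc1c(-c2ccc(O)cc2)nc(SCC(=O)Nn2c(COc3ccc(Cl)cc3Cl)nc3ccccc3c2=O)[nH]c1=O` gives 68.4% in this assay, the only measured step being a number 3.5 percentage points higher from compound 1 to compound 2 (within the scatter). Compound 3 `N#Cc1c(-c2ccc(Cl)cc2)nc(SCC(=O)Nn2c(COc3ccc(Cl)cc3Cl)nc3ccccc3c2=O)n(Cc2ccccc2)c1=O` differs from compound 1 by benzyl in place of hydrogen on an aromatic nitrogen. Among the measured compounds shown here, no measured step touches this place or this group; the one step known, a substituent exchange on an aromatic carbon, stayed within the scatter and offers no direction. For compound 3 in this assay an estimate of 62% (range 48% to 76%) is therefore expected, the expected step being a number 2.9 percentage points lower from compound 1 to compound 3 (within the scatter), no larger than the scatter.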

Compound 3, a percentage reported as inhibition, in the whole organism at one dose (the size of the read-out at that dose, not a potency): 77.2%
Compound 3: the middle estimate sits 15.2 percentage points below what was measured; measured number above the stated range.
By their numbers in this assay, from the lowest: compounds 1, 2 and 3 (each within the scatter of the next, the first and the last beyond it).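

In this assay, within the data shown here, benzyl in place of hydrogen on the aromatic nitrogen gives a number 12.3 percentage points higher from compound 1 to compound 3 (beyond the scatter) and is the only step so far that lies beyond the scatter. The hydrogen on this nitrogen is therefore not required for the effect at this dose, and this position, unlike the aromatic carbon exchange, shows a modest response to substitution. Nothing measured on these compounds accounts for the step. As far as these compounds go, whether methyl, phenethyl or an aminoethyl chain on the same nitrogen would give a similar number remains open. Also open, from the compounds shown here alone, is how benzyl at this position behaves alongside the hydroxy group of compound 2.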